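Swapping a pyrazole for cyclopropyl on an amide nitrogen

The source may report more compounds than this note shows. Statements on the series, on what has been measured and on what is new or still open speak of the compounds shown alone.

Measured compounds:
compound 1, `Cc1ccc(OCC(=O)N(Cc2cccs2)c2cnn(C)c2)cc1`: 63000 nM
compound 2, `Cc1ccc(OCC(=O)N(Cc2cccs2)c2ccnn2C)cc1`: 422 nM
compound 3, `CCN(Cc1cccs1)C(=O)COc1ccc(Cl)cc1`: 39 nM

In an assay on HEK293 cells for agonist activity at transient receptor potential cation channel subfamily M member 8 (Homo sapiens), read by fluorescence and calcium flux, with a stated time of 15 min (a lower number here means that less compound is needed, a higher number that more compound is needed for the effect), compound 2 sits second highest of the three numbers. Compound 3 gives 39 nM, a lower number than compound 2, while compound 1 gives 63000 nM, far higher. The one step that connects two of these compounds by a single change runs a 150-fold lower number from compound 1 to compound 2 (2.17 log units; beyond the scatter), showing that what sits on the amide-type nitrogen can move the read-out strongly.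

Compound 4, `Cc1ccc(OCC(=O)N(Cc2cccs2)C2CC2)cc1`, differs from compound 2 only at that same position: cyclopropyl in place of 1-methyl-1H-pyrazol-5-yl on an amide-type nitrogen. For the measured compounds named here, no measured step covers this particular change, so the measured step between compound 1 and compound 2 bears on it only by showing that this position is sensitive. Compound 3, which has a small saturated group on its amide-type nitrogen, gives the lowest number seen, but it also differs from compound 2 elsewhere, so only its value can be noted. On this basis a modest lower number is expected for compound 4, a step of a 2.1-fold lower number from compound 2 to compound 4 (0.32 log units; beyond the scatter).

The estimate for compound 4 in this assay is 200 nM, with a range from 60 nM to 700 nM.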

Compound 4, half-maximal effective concentration: 8 nM
The estimate for compound 4 lay 25-fold (1.40 log units) above the measured number; measured number below the stated range.
By their numbers in this assay, from the lowest: compound 4; then compound 3; then compound 2; then compound 1.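

In this assay, the position on the amide-type nitrogen proves to be more than a choice between two pyrazole attachments: replacing the 1-methyl-1H-pyrazol-5-yl with cyclopropyl gives a 53-fold lower number from compound 2 to compound 4 (1.72 log units; beyond the scatter), so a non-aromatic ring of carbon only is accepted here and gives the lowest number of the three compounds that differ only at this place. Measured against the other pyrazole, the same swap gives a 7900-fold lower number from compound 1 to compound 4 (3.90 log units; beyond the scatter), which shows how wide the span at this single position can be. The change alters several things at once, going from 6 heavy atoms to 3, from 2 hydrogen-bond acceptors to 0 and from an aromatic ring to a non-aromatic one, and nothing available separates these or explains the large shift.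

As far as these compounds go, it remains open whether the low number belongs to the three-membered ring itself or would also be reached with cyclobutyl, an isopropyl chain or a ring carrying an amine. Compound 3 has ethyl on this nitrogen but also differs elsewhere, so it cannot settle that question.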